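The source may hold more compounds than are shown below. What is called first, only, known or untested is meant among the compounds shown, and "the series" means these compounds.

Measured compounds:
compound 1 `CC1=CC[C@H](C(C)(C)NC(=S)N/N=C/c2ccc(O)cc2)CC1` — a limit, > 100000 nM
compound 2 `CC1=CC[C@H](C(C)(C)NC(=S)N/N=C/c2cccc(Cl)c2)CC1` — a limit, > 100000 nM

In a functional assay on NCI/ADR-RES cells (Homo sapiens) for inhibition, read by sulforhodamine B assay, with a stated time of 48 h (a higher number here means a weaker inhibitor of growth, a lower number a stronger inhibitor of growth), compound 1 reaches only a limit of the assay, > 100000 nM. In this assay compound 2 likewise reaches only a limit, > 100000 nM. Within the data shown here, compound 1 therefore stands at no number at all, and the same holds for the one other value shown, so that the limit of > 100000 nM in this assay, at which 2 of the 2 values shown sit, describes everything measured. Among the measured compounds shown here, the only measured step, a step that the two limits leave unreadable from compound 1 to compound 2, cannot be read, since both ends sit at the limit.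

Compound 3 `COc1cc(/C=N/NC(=S)NC(C)(C)[C@H]2CC=C(C)CC2)ccc1O` differs from compound 1 by methoxy in place of hydrogen on an aromatic carbon. No measured step bears on this change, and the one step shown gives no size to carry over. With nothing pointing either way, compound 3 is expected to show a number no higher from compound 1 to compound 3 (the limit leaves the size open), that is, no readable step, and most likely another limit. The estimate for compound 3 in this assay is 100000 nM, with a range from 30000 nM to 300000 nM.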

Compound 3, concentration for total growth inhibition: > 100000 nM
Compound 3: no number, only a limit (the forecaster's own chance of this, stated with the estimate: 80%); the middle value lies on the limit itself.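

Compound 3 gives only a limit, as compound 1 does, so the step between these two compounds cannot be read: the limit of > 100000 nM in this assay, at which 3 of the 3 values shown sit.

The compounds shown leave open whether in this assay the methoxy change has any effect at all, and of what size.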